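A few compounds are considered here, and "the series" means these few. Any claim that something is new, unique, unknown or untested is made for them only; others in the source may bear on it.

Compound 1 `O=C(O)Cc1sc(C(c2ccc(F)cc2)c2ccc(F)cc2)nc1-c1ccnc(N2CCC2)c1` gives > 100000 nM in an in vitro functional assay on HEK285-7 cells for antagonist activity at prostaglandin D2 receptor 2 (Homo sapiens), read by BRET and beta-arrestin recruitment; on this read-out lower numbers stand for stronger inhibition and higher numbers for weaker inhibition. Compound 2 `O=C(O)Cc1sc(C(c2ccccc2)c2ccccc2)nc1-c1ccc(F)c(F)c1` gives 43 nM in this assay.

Compound 1 stands at the limit of > 100000 nM in this assay, at which 1 of the 2 values shown sits, a limit of the assay and not a number. Within the data shown here, compound 2 differs from compound 1 in more than one place, so the pair shows only that one compound reads a number and the other a limit. Compound 3 `O=C(O)Cc1sc(C(c2ccc(F)cc2)c2ccc(F)cc2)nc1-c1ccncc1` is not yet measured; it differs from compound 1 by hydrogen in place of azetidin-1-yl on an aromatic carbon. From a limit, any step can only run toward stronger inhibition or stay within the scatter; the step expected from compound 1 to compound 3 is an at least 20-fold lower number from compound 1 to compound 3 (1.30 log units; beyond the scatter). Compound 3 is estimated at 5000 nM, between 200 nM and 100000 nM.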

Compound 3, half-maximal inhibitory concentration: 40 nM
Compound 3: middle estimate off by 130-fold (2.10 log units), on the high side; measured number outside the range, below it.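

Hydrogen in place of azetidin-1-yl next to the ring nitrogen gives an at least 2500-fold lower number from compound 1 to compound 3 (3.39 log units; beyond the scatter) in this assay, so the whole gap in this pair rests on this one place on the pyridin-4-yl ring. Compound 3 reads a number here, which shows that the core of compound 1 can inhibit without this group. Compound 1 reads a limit and not a number, so the step is only a bound: the limit of > 100000 nM in this assay, at which 1 of the 3 values shown sits.

On these data alone, what stays open is how much of a group this place can carry: a methyl, a methoxy or an open-chain dimethylamino here would begin to show that.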